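A few compounds are considered here, and "the series" means these few. Any claim that something is new, unique, unknown or untested is made for them only; others in the source may bear on it.

Working notes on the series. Within the data shown here, in a functional assay on HepG2 cells (Homo sapiens) for cytotoxicity, read by MTT assay, with a stated time of 72 h (on this read-out lower numbers stand for higher toxicity in this test and higher numbers for lower toxicity in this test), compound 2 `O=C(/N=C(/NC(=O)c1cc(-c2ccccc2)nc2ccccc12)[Se]Cc1ccccc1)c1cc(-c2ccccc2)nc2ccccc12` gives 78900 nM, the only value that is a number rather than a limit. Compound 1 `CS/C(=N\C(=O)c1sccc1Cl)NC(=O)c1sccc1Cl` sits at a limit of the assay, > 100000 nM. Compound 3 `C[Se]/C(=N\C(=O)c1ccno1)NC(=O)c1ccno1` likewise sits at a limit, > 100000 nM. Thus (the limit of > 100000 nM in this assay, at which 2 of the 3 values shown sit), and compound 2 stands alone as the sole numerical point.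

Compound 4 `CS/C(=N\C(=O)c1cc(-c2ccccc2)nc2ccccc12)NC(=O)c1cc(-c2ccccc2)nc2ccccc12` is not yet measured. It differs from compound 2 by a group of 2 heavy atoms (1 carbon, 1 sulfur; no ring) in place of a group of 8 heavy atoms (7 carbon, 1 selenium; one six-membered aromatic ring of carbon only), on a carbon with a double bond to nitrogen, in words: a group of 2 heavy atoms (1 carbon, 1 sulfur; no ring) in place of a group of 8 heavy atoms (7 carbon, 1 selenium; one six-membered aromatic ring of carbon only), on a carbon with a double bond to nitrogen. Among the measured compounds shown here, no measured pair differing in one place exists, so the size of this step has no anchor. Compound 1 carries methylsulfanyl on the corresponding carbon, and so does compound 3, each with a different core. The expected step of a 1.9-fold higher number from compound 2 to compound 4 (0.28 log units; within the scatter) points toward lower toxicity, probably beyond the scatter. For compound 4 the estimate in this assay is 150000 nM, with a range from 60000 nM to 400000 nM.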

Compound 4, concentration lethal to 50% of the cells: > 100000 nM
Compound 4: no number, only a limit (the forecaster's own chance of this, stated with the estimate: 60%); the middle value does not contradict the limit.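

In this assay, among these compounds, the change on the carbon with a double bond to nitrogen gives the only step that can be read, an at least 1.2-fold higher number from compound 2 to compound 4 (0.10 log units; that floor lies within the scatter). That floor does not establish a real difference, so the swap to methylsulfanyl can be called neither a gain nor a loss in toxicity in this test. On the shared core, the group carrying selenium and the carbon-only aromatic ring gives a number while methylsulfanyl gives only a limit, and the true size of the step stays unknown: the limit of > 100000 nM in this assay, at which 3 of the 4 values shown sit.

From the compounds shown here alone, the change removes selenium and the aromatic ring at once, so which of them matters here remains open. A benzylsulfanyl group on this carbon would separate the two, and an amine there would test a different kind of group.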